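A few compounds are considered here, and "the series" means these few. Any claim that something is new, unique, unknown or untested is made for them only; others in the source may bear on it.

Measured in a functional assay on J82 cells (Homo sapiens) for cytotoxicity, read by colorimetric assay and MTT assay; on this read-out lower numbers stand for stronger inhibition and higher numbers for weaker inhibition:
Compound 1 `COc1cccc2cc(-c3ccccc3)c(O)nc12`: 10000 nM
Compound 2 `CCOC(=O)Cn1c(=O)c(-c2ccc(OC)cc2)cc2c(OC)cc(OC)cc21`: 10000 nM

Compound 2, at 10000 nM, stands level with compound 1, and the two values lie within the scatter of each other. Compound 3 `CCN(CC)C(=O)Cn1c(=O)c(-c2ccc(OC)cc2)cc2c(OC)cc(OC)cc21` keeps the core of compound 2 and differs from it by diethylamino in place of ethoxy on a carbonyl carbon, with diethylamino in place of ethoxy on a carbonyl carbon. Going by the values given here, no measured pair shows a change of this kind, so the expectation in this assay is tentative: a small move toward stronger inhibition, perhaps none beyond the scatter. The estimated change is a 1.4-fold lower number from compound 2 to compound 3 (0.15 log units; within the scatter). Compound 3 is expected at 7000 nM, with an estimated range of 1500 nM to 20000 nM.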

Compound 3, half-maximal inhibitory concentration: 10000 nM
Estimate against measurement, compound 3: 1.4-fold (0.15 log units) below; the measured number falls inside the stated range.
By their numbers in this assay, from the lowest: compounds 1, 2 and 3 (each within the scatter of the next).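

In this assay, going by these compounds alone, diethylamino in place of ethoxy on a carbonyl carbon gives no change at the digits printed from compound 2 to compound 3 (within the scatter) and is the first step that can be read at this position. Going from ethoxycarbonyl to diethylcarbamoyl on the same saturated chain carbon therefore does not separate the two compounds on this read-out. Nothing on hand bears on why this is so.

Going by these compounds, whether a carboxylic acid, a smaller amine such as methylamino, or a longer chain on this carbonyl carbon would shift the number in this assay remains open.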